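Iodo for Propyl on the Aryl Urea

The source may report more compounds than this note shows. Statements on the series, on what has been measured and on what is new or still open speak of the compounds shown alone.

Compound 2 `CCCc1ccc(NC(=O)N[C@@H](C)c2ccccc2)cc1` gives 76% in an ADME assay on the whole organism with Oryza sativa as the target, tested at 1 uM (a lower number here means a stronger effect, a higher number a weaker effect of the compound at the concentration tested), the second highest of the three numbers recorded. Compound 1 `CCCc1ccc(NC(=O)N[C@H](C)c2ccccc2)cc1` gives 31%, and the shift a number 45 percentage points higher from compound 1 to compound 2 (beyond the scatter) rests only on the configuration as drawn (the fact that compounds 1 and 2 differ only in the configuration as drawn). Compound 3 `C[C@H](NC(=O)Nc1ccccc1C(F)(F)F)c1ccccc1` gives 98%, a number that stands above compound 2. The step to compound 4 `C[C@H](NC(=O)Nc1ccc(I)cc1)c1ccccc1` is iodo in place of propyl on an aromatic carbon, placed on an aromatic carbon of a six-membered aromatic ring of carbon only. No measured step involves a change of this kind, so the one shown step offers no guide. With no bearing evidence, compound 4 is expected near the level of compound 2, with a step of no change at the digits printed from compound 2 to compound 4 (within the scatter). The estimate for compound 4 in this assay is 76%, from 45% to 100%.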

Compound 4, a percentage reported as activity, at one concentration (the size of the read-out at that concentration, not a potency): 97%
For compound 4 the middle estimate is 21 percentage points below the measured one; the measured number falls inside the stated range.
By their numbers in this assay, from the lowest: compound 1; then compound 2; then compounds 4 and 3 (each within the scatter of the next).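

In this assay, among the compounds shown here, the exchange of propyl for iodo on an aromatic carbon, para to a large group, gives a number 21 percentage points higher from compound 2 to compound 4 (beyond the scatter) and is the first change of group at this position, where the earlier step showed only a change of configuration. For the compounds shown here, the single step shows that this position responds to a change of group, but nothing available accounts for its size. Open remain how an amine, a carboxylic acid or a longer chain at this position would read in this assay and whether iodo would move the number the same way in the opposite configuration as drawn.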